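Cyclohexyl in place of hexyl: expectation for compound 4

The compounds below may be only part of what the source reports. "The series", "measured", "known", "first", "only" and "open" are said of these compounds alone.

Measured compounds:
Compound 1, `Cc1nc(N)sc1CCCN/C(N)=N/C(=O)N[C@H](C)c1ccccc1`, gives 45.7 nM in a functional assay on HEK293T cells for agonist activity at histamine H2 receptor (Homo sapiens), read by beta-arrestin recruitment; on this read-out lower numbers stand for an effect already at smaller amounts and higher numbers for an effect only at larger amounts of compound.
Compound 2, `CCCCCCNC(=O)/N=C(\N)NCCCc1sc(N)nc1C`, gives 85.1 nM in this assay.
Compound 3, `Cc1nc(N)sc1CCCN/C(N)=N/C(=O)NCC(C)C1CCCCC1`, gives 224 nM in this assay.

Compound 2 stands second highest of the three numbers. Its nearest neighbour is compound 1, with a 1.9-fold higher number from compound 1 to compound 2 (0.27 log units; within the scatter), a step that stays within the scatter; its furthest is compound 3, with a 2.6-fold higher number from compound 2 to compound 3 (0.42 log units; beyond the scatter), a modest step beyond the scatter.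

Compound 4, `Cc1nc(N)sc1CCCN/C(N)=N/C(=O)NC1CCCCC1`, differs from compound 2 by cyclohexyl in place of hexyl on an amide-type nitrogen.

For the measured compounds named here, two measured steps bear on this change. The step of a 1.9-fold higher number from compound 1 to compound 2 (0.27 log units; within the scatter) shows that exchanging one substituent on the amide-type nitrogen for another of similar size left the number essentially unchanged. The step of a 2.6-fold higher number from compound 2 to compound 3 (0.42 log units; beyond the scatter) shows that bringing in a six-membered non-aromatic carbon ring in that region raised the number modestly. Compound 4 likewise brings in such a ring, so a small rise in this assay is expected for compound 4, near the edge of the scatter, as a 1.5-fold higher number from compound 2 to compound 4 (0.18 log units; within the scatter). The estimate for compound 4 is 130 nM, with a range from 55 nM to 310 nM.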

Compound 4, half-maximal effective concentration: 389 nM
Compound 4: the middle estimate sits 3.0-fold (0.48 log units) below what was measured; the whole stated range lies below it.
By their numbers in this assay, from the lowest: compounds 1 and 2 (each within the scatter of the next); then compounds 3 and 4 (each within the scatter of the next).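

In this assay, cyclohexyl in place of hexyl on the amide-type nitrogen is not a neutral exchange: it brings a 4.6-fold higher number from compound 2 to compound 4 (0.66 log units; beyond the scatter), even though both groups hold the same count of heavy atoms. Cyclohexyl in place of 1-phenylethyl at the same place brings an 8.5-fold higher number from compound 1 to compound 4 (0.93 log units; beyond the scatter), so this position does not accept every six-carbon or ring-bearing group alike. Compound 3 and compound 4, the two compounds carrying a cyclohexyl ring, now stand within the scatter of each other and above compound 1 and compound 2, and no supporting measurement speaks to why this is so.

Going by these compounds, it remains open whether this rise belongs to cyclohexyl alone or extends to other rings, such as cyclopentyl or phenyl on the amide-type nitrogen. On these data alone, the effect of an amine or a hydroxyl on the cyclohexyl ring is also open.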